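The source may report more compounds than this note shows. Statements on the series, on what has been measured and on what is new or still open speak of the compounds shown alone.

In an ADME assay on HOS cells (Homo sapiens) for cytotoxicity (on this read-out higher numbers stand for lower toxicity in this test and lower numbers for higher toxicity in this test), compound 1 `CN(Cc1nc2ccccc2n1C[C@H]1CCCN(Cc2cccnc2)C1)[C@H]1CCCc2cccnc21` gives 2500 nM and compound 2 `CN1CCC[C@@H](Cn2c(CN(C)[C@H]3CCCc4cccnc43)nc3ccccc32)C1` gives 3500 nM, so compound 2 stands level with compound 1 within the scatter. Compound 3 `CC(C)CCN1CCC[C@H](Cn2c(CN(C)[C@H]3CCCc4cccnc43)nc3ccccc32)C1` has 1-isopentylpiperidin-3-yl in place of 1-methylpiperidin-3-yl on a saturated chain carbon bound to an aromatic nitrogen. Among the compounds with values here, no measured single-change step is available to guide the estimate. In this assay, a small fall in the number, within the scatter, is expected, with the estimated step being a 1.8-fold lower number from compound 2 to compound 3 (0.24 log units; within the scatter). For compound 3 the estimated value is 2000 nM, with an expected range from 600 nM to 7000 nM.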

Compound 3, half-maximal cytotoxic concentration: 2300 nM
Compound 3: middle estimate off by 1.2-fold (0.06 log units), on the low side; the range from low to high includes it.
By their numbers in this assay, from the lowest: compounds 3, 1 and 2 (each within the scatter of the next).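

In this assay, 1-isopentylpiperidin-3-yl in place of 1-methylpiperidin-3-yl on a saturated chain carbon bound to an aromatic nitrogen gives a 1.5-fold lower number from compound 2 to compound 3 (0.18 log units; within the scatter), so this position tolerates the change without a step beyond the scatter. Isobutyl in place of pyridin-3-yl on a saturated chain carbon bound to an amine nitrogen in a ring gives a 1.1-fold lower number from compound 1 to compound 3 (0.04 log units; within the scatter), so these two groups are not separated either. Nothing available accounts for either step. Going by these compounds, how a carboxylic acid or a primary amine in place of isobutyl would read in this assay remains open.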